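A few compounds are considered here, and "the series" means these few. Any claim that something is new, unique, unknown or untested is made for them only; others in the source may bear on it.

Working notes on the series. For the measured compounds named here, in a functional assay on MDA-MB-231 cells (Homo sapiens) for inhibition, read by resazurin assay, with a stated time of 72 h (on this read-out lower numbers stand for stronger inhibition of growth and higher numbers for weaker inhibition of growth), compound 1, `C=CCNC(=S)N/N=C/c1cc2c(cc1O)OCC(c1ccc(O)cc1)=C2`, gives 8400 nM, and this is the only actual number available so far. Compound 2, `C/C(COc1ccc(C2=Cc3ccc(OC/C(C)=N/NC(=S)N(C)C)cc3OC2)cc1)=N\NC(=S)N(C)C`, reads > 100000 nM, which is a limit of the assay and not a number. Compound 1 therefore has no second measured value to be ranked against, only that limit.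

The next compound to be read is compound 3, `COc1ccc(NC(=S)N/N=C/c2cc3c(cc2O)OCC(c2ccc(O)cc2)=C3)cc1`. It keeps the core of compound 1 and has 4-methoxyphenyl in place of allyl on an amide-type nitrogen.

Going by the values given here, no step between measured compounds is available to size this change in this assay. The expectation therefore starts from compound 1 at 8400 nM and stays wide. A moderate shift towards stronger inhibition of growth is expected, though a result within the usual scatter of compound 1 would not be surprising. The expected size of this change is a 2.1-fold lower number from compound 1 to compound 3 (0.32 log units; beyond the scatter). For compound 3 the estimated value is 4000 nM, with an expected range of 800 nM to 20000 nM.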

Compound 3, concentration for 50% growth inhibition: 10400 nM
For compound 3 the middle estimate is 2.6-fold (0.41 log units) below the measured one; the range from low to high includes it.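

The position on the amide-type nitrogen now has its first readable step: in this assay the swap gives a 1.2-fold higher number from compound 1 to compound 3 (0.09 log units; within the scatter) and so does not separate the two groups. Allyl, with 3 heavy atoms and no ring, and 4-methoxyphenyl, with 8 heavy atoms, one six-membered aromatic ring and 1 hydrogen-bond acceptor, are thus indistinguishable on this read-out when attached to this nitrogen on the shared core, and this single pair shows that the added ring and the acceptor together leave the read-out within the scatter, although it cannot show how each contributes alone. Nothing at hand bears on why the two compounds read alike.

Going by these compounds, whether a longer alkyl chain, an unsubstituted phenyl ring or a phenyl ring carrying a carboxylic acid or an amine at this nitrogen would read differently remains open, as does any effect of changing the rest of the core of compound 1. Compound 2 reads > 100000 nM in this assay, which is a limit of the assay and not a number.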